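Working notes: the step from compound 2 to compound 4

The source may report more compounds than this note shows. Statements on the series, on what has been measured and on what is new or still open speak of the compounds shown alone.

Measured so far in a functional assay on DU-145 cells (Homo sapiens) for antiproliferative activity, read by propidium iodide staining, with a stated time of 96 h; on this read-out lower numbers stand for stronger inhibition and higher numbers for weaker inhibition:
- compound 1 `CC(O)(COc1ccc(S(F)(F)(F)(F)F)cc1)C(=O)Nc1ccc([N+](=O)[O-])c(C(F)(F)F)c1` gives 21200 nM
- compound 2 `CC(O)(COc1ccc(S(F)(F)(F)(F)F)cc1)C(=O)Nc1cc(C(F)(F)F)cc(C(F)(F)F)c1` gives 6500 nM
- compound 3 `CC(O)(CS(=O)(=O)c1ccccc1OC(F)(F)F)C(=O)Nc1ccc(S(F)(F)(F)(F)F)cc1` gives 19500 nM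

Compound 2 (6500 nM) has the lowest number of the three, and its gaps to compound 1 and to compound 3 both lie beyond the scatter. The values of compound 1 and compound 3 lie within the scatter of each other.

Compound 4 `CC(O)(COc1ccc(C(F)(F)C(F)(F)F)cc1)C(=O)Nc1cc(C(F)(F)F)cc(C(F)(F)F)c1` departs from compound 2 in one place: a group of 7 heavy atoms (2 carbon, 5 fluorine; no ring) in place of a group of 6 heavy atoms (5 fluorine, 1 sulfur; no ring), on an aromatic carbon. The change sits on an aromatic carbon of a six-membered aromatic ring of carbon only, para to a large group, and 1,1,2,2,2-pentafluoroethyl is the group that enters. Neither the leaving nor the entering group has a ring or a net charge. Among the compounds with values here, no measured pair in this set isolates this exchange, so the expectation rests on the structural change alone, and it is a weakly supported one.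

No step beyond the scatter is expected in this assay here. The estimated move is a 1.1-fold higher number from compound 2 to compound 4 (0.03 log units; within the scatter) and would stay within the scatter. Compound 4 is expected at 7000 nM (estimated range 3000 nM to 16000 nM).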

Compound 4, half-maximal inhibitory concentration: 6800 nM
Beside the measured number, compound 4's estimate is 1.0-fold (0.01 log units) above it; measured number inside the range.
By their numbers in this assay, from the lowest: compounds 2 and 4 (each within the scatter of the next); then compounds 3 and 1 (each within the scatter of the next).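

In this assay, putting 1,1,2,2,2-pentafluoroethyl in place of the group of 5 fluorine and 1 sulfur, on an aromatic carbon para to a large group, gives a 1.0-fold higher number from compound 2 to compound 4 (0.02 log units; within the scatter), so at this place on the shared core the two groups cannot be told apart in this read-out. Within the data shown here, this is the only pair that differs in one place, and it gives a direct reading of this position that compounds 1, 2 and 3 alone could not give. Nothing at hand bears on why the two groups read alike.

Going by these compounds, the reading covers just these two groups at this place, so it stays open whether an amine, a carboxylic acid or a longer perfluoroalkyl chain there would stay within the scatter of compound 2, which gives 6500 nM. On these data alone, it also stays open whether the same exchange would read alike on the core of compound 1, which carries a nitro group on its anilide ring.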